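This account rests on a few compounds, and the source may have more. Where it says the series, first, only, none or still open, it means among the compounds named here.

Compound 1 `COc1cc(/C=C/C(=O)c2cccc(-n3cc(-c4ccc(Cl)cc4)[nH]c3=O)c2)cc(OC)c1OC`: 4100 nM in a functional assay on NCI-H522 cells (Homo sapiens) for inhibition; on this read-out higher numbers stand for weaker inhibition of growth and lower numbers for stronger inhibition of growth
Compound 2 `O=C(/C=C/c1cccc(O)c1)c1cccc(-n2cc(-c3ccc(Cl)cc3)[nH]c2=O)c1`: 1650 nM

Of the two measured compounds, compound 1 shows the higher number in this assay; compound 2 lies lower, and that gap is beyond the usual scatter. Compound 3 `COc1cc(/C=C/C(=O)c2cccc(-n3cc(-c4cc(OC)c(OC)c(OC)c4)[nH]c3=O)c2)cc(OC)c1OC` has not yet been measured. It differs from compound 1 in one place: 3,4,5-trimethoxyphenyl in place of 4-chlorophenyl on an aromatic carbon. Within the data shown here, no measured pair shows this change, so its effect on growth inhibition is unknown here. Compound 3 is expected to give about 3000 nM in this assay, with a range from 800 nM to 12000 nM. The expected step of a 1.4-fold lower number from compound 1 to compound 3 (0.14 log units; within the scatter) stays within the scatter, with no direction predicted beyond it.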

Compound 3, concentration for 50% growth inhibition: 1050 nM
The estimate for compound 3 lay 2.9-fold (0.46 log units) above the measured number, within the range that was stated.
By their numbers in this assay, from the lowest: compounds 3 and 2 (each within the scatter of the next); then compound 1.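

In this assay the aromatic carbon of the five-membered ring accepts more than 4-chlorophenyl: placing 3,4,5-trimethoxyphenyl there gives a 3.9-fold lower number from compound 1 to compound 3 (0.59 log units; beyond the scatter) with the rest of the molecule unchanged. Among these compounds, this is the first single-place step, and it shows that growth inhibition responds to the group at this position, though only modestly here. No available evidence explains the step. Still open, from the compounds shown here alone, is whether a smaller phenyl group carrying one methoxy, an amine or a carboxylic acid would move the number further, and whether the same exchange would have a similar effect on compound 2.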